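Nitro-to-amino swap in a benzylsulfonyl styrene series

The source may hold more compounds than are shown below. What is called first, only, known or untested is meant among the compounds shown, and "the series" means these compounds.

Measured so far in a functional assay on MDA-MB-468 cells (Homo sapiens) for cytotoxicity, read by MTT assay, with a stated time of 72 h; a lower number here means a stronger inhibitor of growth, a higher number a weaker inhibitor of growth:
compound 1 `COc1ccc(CS(=O)(=O)/C=C/c2c(OC)cccc2OC)cc1[N+](=O)[O-]`: 5460 nM
compound 2 `COc1cc(/C=C/S(=O)(=O)Cc2ccc(OC)c([N+](=O)[O-])c2)cc(OC)c1`: 16500 nM
compound 3 `COc1ccc(CS(=O)(=O)CC(=O)Nc2c(C)cc(C)cc2C)cc1N`: a limit only, > 30000 nM

Compound 2 stands at the higher of the two numbers read; compound 1 sits at a lower number, a gap beyond the scatter. Within the data shown here, compound 3 is the one value that sits at the limit of > 30000 nM in this assay, at which 1 of the 3 values shown sits.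

Compound 4 `COc1cc(/C=C/S(=O)(=O)Cc2ccc(OC)c(N)c2)cc(OC)c1` differs from compound 2 by amino in place of nitro on an aromatic carbon. Among the measured compounds shown here, no measured pair makes this exact step, so its size cannot be read off directly; the only amino-bearing compound, compound 3, sits on a different core and at the limit of > 30000 nM in this assay, at which 1 of the 3 values shown sits. The step from compound 2 to compound 4 is expected to go upward, a 1.7-fold higher number from compound 2 to compound 4 (0.23 log units; within the scatter). Compound 4 is therefore estimated at 28000 nM, within 9000 nM to 90000 nM, with a real chance that this assay returns only a limit.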

Compound 4, concentration for 50% growth inhibition: 520 nM
Estimate against measurement, compound 4: 54-fold (1.73 log units) above; the whole stated range lies above it.
By their numbers in this assay, from the lowest: compound 4; then compound 1; then compound 2. At a limit, above all of these: compound 3.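

In this assay, amino in place of nitro on this aromatic carbon, ortho to a methoxy group, gives a 32-fold lower number from compound 2 to compound 4 (1.50 log units; beyond the scatter), so the nitro group is not needed here for growth inhibition. Compound 4, at 520 nM, now has the lowest number of the series. Compound 3, also amino-bearing but on a different core, gives only a limit, so the gain cannot be carried across cores: the limit of > 30000 nM in this assay, at which 1 of the 4 values shown sits.

On these data alone, whether an acetylamino or dimethylamino group at this position keeps the gain remains open. So does the size of the same swap on the core of compound 1.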